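The source may hold more compounds than are shown below. What is called first, only, known or untested is meant among the compounds shown, and "the series" means these compounds.

Measured so far:
compound 1 `C=CCNc1nc(NCc2ccc(C(=O)Nc3ccc(F)cc3)cc2)c2cc(C)ccc2n1` — 10000 nM
compound 2 `CC1CN(c2nc(NCc3ccc(C(=O)Nc4ccc(F)cc4)cc3)c3ccccc3n2)CCN1` — 3200 nM

In a functional assay on SW480 cells (Homo sapiens) for inhibition, read by luminescence and resazurin assay, with a stated time of 3 days (a higher number here means a weaker inhibitor, a lower number a stronger inhibitor), compound 2 gives the lowest of the two numbers; compound 1 sits higher by a margin beyond the scatter. Compound 3 `C=CCNc1nc(NCc2ccc(C(=O)Nc3ccc(F)cc3)cc2)c2ccccc2n1` follows from compound 2 by allylamino in place of 3-methylpiperazin-1-yl on an aromatic carbon. Compound 3 also carries the same allylamino group as compound 1, differing from it only at the fused ring. Against compound 2 a clear upward step is expected, since compound 1 with the allylamino group gave 10000 nM. The estimated step of a 2.5-fold higher number from compound 2 to compound 3 (0.40 log units; beyond the scatter) points toward weaker inhibition. For compound 3 the expected value in this assay is 8000 nM, within 3000 nM to 25000 nM.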

Compound 3, half-maximal inhibitory concentration: 11000 nM
Estimate against measurement, compound 3: 1.4-fold (0.14 log units) below; the measured number falls inside the stated range.
By their numbers in this assay, from the lowest: compound 2; then compounds 1 and 3 (each within the scatter of the next).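

In this assay allylamino in place of 3-methylpiperazin-1-yl on the aromatic carbon between two ring nitrogen atoms gives a 3.4-fold higher number from compound 2 to compound 3 (0.54 log units; beyond the scatter) and so moves toward weaker inhibition in a single-place comparison at this position. With allylamino in place, hydrogen in place of methyl on an aromatic carbon gives a 1.1-fold higher number from compound 1 to compound 3 (0.04 log units; within the scatter) and leaves the two compounds alike within the scatter. No measured evidence bears on the cause of either step.

Open, going by these compounds, is whether an unsubstituted piperazin-1-yl, a morpholin-4-yl or a dimethylamino group at this position would read like compound 2 or compound 3. Also open, on these data alone, is whether methyl on the fused ring would read the same alongside 3-methylpiperazin-1-yl.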